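Swapping the Sulfonyl Cap for a Pyrrolidine Amide

A few compounds are considered here, and "the series" means these few. Any claim that something is new, unique, unknown or untested is made for them only; others in the source may bear on it.

Measured in an assay on U2OS cells for inhibition of secreted frizzled-related protein 1 (Homo sapiens), read by a luciferase reporter, with a stated time of 18 h; on this read-out lower numbers stand for an effect already at smaller amounts and higher numbers for an effect only at larger amounts of compound:
Compound 1 `O=C(c1ccccc1)N1CCC(NS(=O)(=O)c2cc(S(=O)(=O)c3ccccc3)ccc2C(F)(F)F)CC1` gives 250 nM.
Compound 2 `O=C(c1cccc(Cl)c1)N1CCC(NS(=O)(=O)c2cc(S(=O)(=O)c3ccccc3)ccc2C(F)(F)F)CC1` gives 870 nM.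
Compound 3 `O=C(O)c1cccc(S(=O)(=O)N2CCC(NS(=O)(=O)c3cc(S(=O)(=O)c4ccccc4)ccc3C(F)(F)F)CC2)c1` gives 190 nM.

Compound 3 has the lowest number of the three, but the gap to compound 1, a 1.3-fold lower number from compound 1 to compound 3 (0.12 log units; within the scatter), lies within the scatter, while the gap to compound 2, a 4.6-fold lower number from compound 2 to compound 3 (0.66 log units; beyond the scatter), lies beyond it. Compound 4 `O=C([C@@H]1CCNC1)N1CCC(NS(=O)(=O)c2cc(S(=O)(=O)c3ccccc3)ccc2C(F)(F)F)CC1` differs from compound 3 by (pyrrolidin-3-yl)carbonyl in place of (3-carboxyphenyl)sulfonyl on an amine nitrogen in a ring. Among the compounds with values here, the steps that bear on this are those that also changed the group on the ring nitrogen: a 1.3-fold lower number from compound 1 to compound 3 (0.12 log units; within the scatter) and a 4.6-fold lower number from compound 2 to compound 3 (0.66 log units; beyond the scatter), the first within scatter, the second modest. Within the data shown here, no measured step covers a non-aromatic group at that position, so a modest rise is expected. Compound 4 is therefore estimated at 450 nM, between 150 nM and 1500 nM, an expected step of a 2.4-fold higher number from compound 3 to compound 4 (0.37 log units; beyond the scatter).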

Compound 4, half-maximal effective concentration: 380 nM
Compound 4: the middle estimate sits 1.2-fold (0.07 log units) above what was measured, within the range that was stated.
By their numbers in this assay, from the lowest: compounds 3, 1 and 4 (each within the scatter of the next); then compound 2.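

In this assay the ring nitrogen carries a non-aromatic (pyrrolidin-3-yl)carbonyl group with no loss beyond the scatter against either aromatic cap without chlorine, with a 2.0-fold higher number from compound 3 to compound 4 (0.30 log units; within the scatter) and a 1.5-fold higher number from compound 1 to compound 4 (0.18 log units; within the scatter). The 3-chlorobenzoyl cap alone stands apart, with a 2.3-fold lower number from compound 2 to compound 4 (0.36 log units; beyond the scatter), a modest step. No evidence given here accounts for these steps. Still open, going by these compounds, is how an open-chain amine, or a carboxylic acid on the pyrrolidine ring, would fare at this position. Also open, on these data alone, is what the opposite configuration at the defined stereocentre would give.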